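Swapping a Methyl for a Phenyl on the Carbonyl

The compounds below may be only part of what the source reports. "The series", "measured", "known", "first", "only" and "open" are said of these compounds alone.

Of the compounds shown here, three built on a shared core have been tested in a functional assay on RPMI-8226 cells (Homo sapiens) for inhibition, read by sulforhodamine B assay, with a stated time of 48 h; on this read-out higher numbers stand for weaker inhibition of growth and lower numbers for stronger inhibition of growth. Compound 1 `COc1ccc(-c2[nH]c3ccccc3c2/C=C(\C#N)S(=O)(=O)c2ccccc2)cc1` gives 2100 nM. Compound 2 `CCOC(=O)C(=Cc1c(-c2ccccc2)[nH]c2ccccc12)C(=O)OCC` gives 219 nM. Compound 3 `CC(=O)/C(=C\c1c(-c2ccccc2)[nH]c2ccccc12)S(=O)(=O)c1ccccc1` gives 2200 nM. Of these three numbers, compound 3 carries the highest. Its nearest neighbour is compound 1, which sits so close that the two cannot be told apart within the usual scatter of this assay. Its furthest neighbour is compound 2, whose number lies well below, a gap that is beyond the scatter.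

Compound 4 `O=C(/C(=C\c1c(-c2ccccc2)[nH]c2ccccc12)S(=O)(=O)c1ccccc1)c1ccccc1` has not yet been measured. It differs from compound 3 in one place: phenyl in place of methyl on a carbonyl carbon. Cut one bond further out, the same change reads acetyl to benzoyl. Within the data shown here, no pair of measured compounds shows this particular change, so its effect in this assay cannot be read from the data in hand. The two compounds that keep the sulfonyl group, compound 1 and compound 3, land close together, which gives no sign that a change at the carbonyl would move the number far.

The step from compound 3 to compound 4 is expected to be a 1.5-fold lower number from compound 3 to compound 4 (0.17 log units; within the scatter), a small shift toward stronger growth inhibition that stays within the scatter. Compound 4 is therefore estimated at 1500 nM, with a likely range from 500 nM to 4500 nM.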

Compound 4, concentration for 50% growth inhibition: 7600 nM
Compound 4: middle estimate off by 5.1-fold (0.70 log units), on the low side, and the stated range ends below it.
By their numbers in this assay, from the lowest: compound 2; then compounds 1 and 3 (each within the scatter of the next); then compound 4.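

In this assay, replacing methyl with phenyl on a carbonyl carbon, which reads as acetyl to benzoyl, gives a 3.5-fold higher number from compound 3 to compound 4 (0.54 log units; beyond the scatter), a shift toward weaker inhibition of growth. Among these compounds, this pair gives the first direct reading at this position and shows that the group on the carbonyl carbon can change the number by more than the usual scatter, even though the earlier compounds gave no way to isolate this change. No measurement presented here accounts for the rise, so the data record the direction and size of this step but not its cause.

With a single pair, the compounds shown leave open whether the rise goes with the six-membered aromatic ring itself or simply with having more atoms on the carbonyl carbon, a question that an ethyl group, a longer chain or a saturated cyclohexyl ring at this place could help to settle. They also leave open what an amine or a hydroxyl group on the same carbonyl carbon, forming an amide or a carboxylic acid, would do to growth inhibition.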